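The source may hold more compounds than are shown below. What is called first, only, known or untested is meant among the compounds shown, and "the series" means these compounds.

The compounds measured so far, each in a functional assay on HUVEC cells (Homo sapiens) (on this read-out lower numbers stand for an effect already at smaller amounts and higher numbers for an effect only at larger amounts of compound), where the value is a limit of the assay:

Compound 1 `COC1=C(C)C(=O)/C(=C(O)/C=C/c2ccc(OC)cc2)C(=O)C1(C)C`: < 4 ug/mL
Compound 2 `COC1=C(C)C(=O)/C(=C(O)/C=C/c2cccc(OC)c2)C(=O)C1(C)C`: < 4 ug/mL
Compound 3 `COC1=C(C)C(=O)/C(=C(O)/C=C/c2ccc(O)cc2)C(=O)C1(C)C`: < 4 ug/mL

Compound 3 stands where every measured compound stands: at a limit rather than a number, and the other two values shown are limits as well. Its neighbours tell little about size, since a step that the two limits leave unreadable from compound 1 to compound 2, a step that the two limits leave unreadable from compound 1 to compound 3 and a step that the two limits leave unreadable from compound 2 to compound 3 all fall between two limits and are unreadable; what is known is the limit of < 4 ug/mL in this assay, at which 3 of the 3 values shown sit.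

Compound 4 `COC1=C(C)C(=O)/C(=C(O)/C=C/c2cc(C)cc(C)c2)C(=O)C1(C)C` is not yet measured. It differs from compound 3 by 3,5-dimethylphenyl in place of 4-hydroxyphenyl on a double-bonded chain carbon bound to a double-bonded chain carbon. Among the measured compounds shown here, no measured step bears readably on this change, so no size or direction can be taken from the steps; the only guide is that all three values sit at the same limit in this assay. Compound 4 is therefore expected to land near that limit, with a step that the limit leaves unreadable from compound 3 to compound 4 likely not beyond the scatter, and its estimated value is 3 ug/mL, within 1 ug/mL to 10 ug/mL.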

Compound 4, concentration for half-maximal effect: < 4 ug/mL
Compound 4: only a limit was reported; the forecaster's own chance of this, stated with the estimate: 55%; the middle value lies beyond the limit too.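

In this assay compound 4 gives < 4 ug/mL, which is a limit of the assay. Its steps from compound 1, compound 2 and compound 3 cannot be read: the limit of < 4 ug/mL in this assay, at which 4 of the 4 values shown sit.

The compounds shown leave open whether their differing phenyl groups change the effect in this assay at all, and by how much.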